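The source may hold more compounds than are shown below. What is called first, only, known or untested is meant among the compounds shown, and "the series" means these compounds.

Series notes. In an assay on HEK293 cells for inhibition of N-acylethanolamine-hydrolyzing acid amidase (Homo sapiens), read by fluorescence, with stated times of 10 min and 30 min (a lower number here means a stronger inhibitor, a higher number a weaker inhibitor), compound 2 `CCCCCCCCCC(=O)N[C@H]1CNC1=O` gives 240 nM. Compound 1 `CC(C)(C)[C@@H]1OC(=O)[C@H]1NC(=O)OCc1ccc(-c2ccccc2)cc1` gives 507 nM in this assay. Of the two numbers, compound 2 carries the lower one, and the number of compound 1 stands beyond the scatter above it. Compound 3 `CCCCCCCCCCC(=O)N[C@H]1CNC1=O` is not yet measured in this assay. It differs from compound 2 in one place: methyl in place of hydrogen on a saturated chain carbon, nine bonds along the chain from a carbonyl carbon, a lengthening of the acyl chain at its far end. Within the data shown here, no step between measured compounds with this kind of change is available in this assay, so the expected direction rests on the structural change alone. For a methyl added at the end of the chain, a step no larger than the scatter is expected, leaning toward a slightly lower number. The estimated step is a 1.3-fold lower number from compound 2 to compound 3 (0.12 log units; within the scatter). Compound 3 is expected to give about 180 nM in this assay, within 70 nM to 450 nM.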

Compound 3, half-maximal inhibitory concentration: 100 nM
The estimate for compound 3 lay 1.8-fold (0.26 log units) above the measured number, within the range that was stated.
By their numbers in this assay, from the lowest: compound 3; then compound 2; then compound 1.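

In this assay the far end of the acyl chain is not a silent position: methyl in place of hydrogen on a saturated chain carbon, nine bonds along the chain from a carbonyl carbon, gives a 2.4-fold lower number from compound 2 to compound 3 (0.38 log units; beyond the scatter) and so lies beyond the scatter. Among these compounds, this is the first step readable, since compound 1 differs from compound 2 in more than one place and offered no comparison for this change. Nothing available explains why this one added carbon lowers the number.

On these data alone, a single step sets no trend, so it remains open whether a longer chain would lower the number further or reverse the change. Also open, as far as these compounds go, is how a hydroxyl, an amine or a carboxylic acid at the chain end would compare with methyl at this position.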